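Bromo to nitro on the aryl ring of compound 1

The source may report more compounds than this note shows. Statements on the series, on what has been measured and on what is new or still open speak of the compounds shown alone.

Compound 1 `O=C(COc1ccc(C(=O)/C=C/c2cccc(Br)c2)cc1)N[C@H]1CCOC1=O` is the reference point of this small set. Going by the values given here, in a functional assay on DU-145 cells (Homo sapiens) for antiproliferative activity, read by MTT assay, with a stated time of 72 h (a lower number here means a stronger inhibitor, a higher number a weaker inhibitor), compound 1 gives 9800 nM, the lowest of the two numbers measured so far. Compound 2 `O=C1OCC[C@@H]1NC(=S)SCCOc1ccccc1[N+](=O)[O-]` gives 33400 nM in this assay, a result that sits beyond the usual scatter from compound 1. Compound 3 `O=C(CNc1ccc(F)cc1)N[C@H]1CCOC1=O` reaches only a limit of the assay, > 64000 nM, and no number; this is the limit of > 64000 nM in this assay, at which 1 of the 3 values shown sits.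

Compound 4 `O=C(COc1ccc(C(=O)/C=C/c2cccc([N+](=O)[O-])c2)cc1)N[C@H]1CCOC1=O` has not yet been measured. It differs from compound 1 in one place: nitro in place of bromo on an aromatic carbon. No measured pair in the set shows a comparable exchange, so the size of this step is not anchored by any shown data. With only the value of compound 1 to rest on, the number for compound 4 is expected to stay close to that of compound 1, with a step of a 1.2-fold higher number from compound 1 to compound 4 (0.09 log units; within the scatter) that need not exceed the scatter. Compound 4 is therefore estimated at 12000 nM in this assay, within a range from 4000 nM to 40000 nM.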

Compound 4, half-maximal inhibitory concentration: 41800 nM
For compound 4 the middle estimate is 3.5-fold (0.54 log units) below the measured one, and the stated range ends below it.
By their numbers in this assay, from the lowest: compound 1; then compounds 2 and 4 (each within the scatter of the next). At a limit, above all of these: compound 3.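

In this assay, going by these compounds alone, the exchange of 3-bromophenyl for 3-nitrophenyl gives the first one-place step, and it is not neutral: a 4.3-fold higher number from compound 1 to compound 4 (0.63 log units; beyond the scatter). The aromatic carbon meta to a large group therefore responds to the group it carries, and of the two groups shown, bromo gives the lower number. Compound 4 still gives a number, so the step can be read in full, whereas compound 3 alone stands at a limit of the assay, which is not a number: the limit of > 64000 nM in this assay, at which 1 of the 4 values shown sits.

A single exchange does not tell whether the rise belongs to nitro in particular or would follow any replacement of bromo. From the compounds shown here alone, how an amine, a carboxylic acid or a methoxy group would read on this same aromatic carbon remains open.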